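Removing the cyclohexyl group from compound 3

This account rests on a few compounds, and the source may have more. Where it says the series, first, only, none or still open, it means among the compounds named here.

In an ADME assay on MDBK cells (Bos taurus) for cytotoxicity, read by MTT assay, with a stated time of 96 h (a higher number here means that more compound is tolerated, a lower number that less compound is tolerated), compound 3 (`CC(=O)c1ccc2c(c1)nc(-c1ccoc1)n2C1CCCCC1`) gives > 100000 nM as a limit of the assay and not a number. The whole set sits together (the limit of > 100000 nM in this assay, at which 3 of the 3 values shown sit) and no exact number exists for any member. Compound 2 (`CC(=O)c1ccc2c(c1)nc(-c1ccc(Cl)cc1)n2C1CCCCC1`) gives > 100000 nM as a limit too.

Compound 4 (`CC(=O)c1ccc2[nH]c(-c3ccoc3)nc2c1`) has not yet been measured. It carries hydrogen in place of cyclohexyl on an aromatic nitrogen and keeps the furan-3-yl group of compound 3.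

Among the compounds with values here, the one measured step, furan-3-yl in place of 4-chlorophenyl, is a step that the two limits leave unreadable from compound 2 to compound 3 and so offers no size to carry over. The nearest guide is compound 1 (`CC(=O)c1ccc2[nH]c(-c3ccccc3)nc2c1`), which also has hydrogen in place of cyclohexyl and gives > 100000 nM as a limit. No step beyond the usual scatter is therefore expected in this assay and a further limit is the likeliest report. The expected step is a number no higher from compound 3 to compound 4 (the limit leaves the size open) as an estimate resting on these limits alone. For compound 4 the estimated half-maximal cytotoxic concentration is 100000 nM with an expected range from 50000 nM to 100000 nM on this reasoning.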

Compound 4, half-maximal cytotoxic concentration: >= 100000 nM
Compound 4: a limit, no number; the forecaster's own chance of this, stated with the estimate: 75%; the middle value sits exactly at the limit.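

Compound 4 gives only a limit of the assay, as do compound 1 and compound 3, so no step can be read from compound 3 or compound 1 to compound 4. In this assay, the compounds shown leave open the actual half-maximal cytotoxic concentration of each one, and whether swapping either group changes it.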